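This account rests on a few compounds, and the source may have more. Where it says the series, first, only, none or still open, it means among the compounds named here.

Working notes on a functional assay on HT-22 cells (Mus musculus), read by MTT assay, with a stated time of 24 h (on this read-out higher numbers stand for an effect only at larger amounts of compound and lower numbers for an effect already at smaller amounts), follow. Among the measured compounds shown here, compound 2 `Cc1cc(O)c(C(=O)/C=C/c2ccc(O)c(O)c2)cc1C` gives 50 nM as the only number in the set. Compound 1 `COc1ccc(-c2cc(OC)c3ccccc3n2)cc1O` is recorded as "not active" (no number reported) and offers no number. Compound 3 `CCOc1ccc(/C=C/C(=O)c2ccc3ccccc3c2O)cc1OCC` is recorded as "not active" (no number reported) and likewise offers no number. For the measured compounds named here, no step between two measured compounds is therefore available, and the size of any change has to be estimated. Compound 4 `COc1ccc(/C=C/C(=O)c2cc(C)c(C)cc2O)cc1O` awaits measurement and differs from compound 2 by one change: methyl in place of hydrogen on an oxygen on an aromatic ring which turns a hydroxy into a methoxy. Compound 1 also carries a methoxy on an aromatic ring and reads "not active" (no number reported) on a different core, so it offers only weak guidance. The expected step is an 8.0-fold higher number from compound 2 to compound 4 (0.90 log units; beyond the scatter) in the direction of larger amounts of compound and beyond the usual scatter. A result without a number is also a real possibility for compound 4. Compound 4 is estimated at 400 nM with an expected range from 100 nM to 3000 nM in this assay once measured.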

Compound 4, half-maximal effective concentration: 200 nM
Beside the measured number, compound 4's estimate is 2.0-fold (0.30 log units) above it, within the range that was stated.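

In this assay, among the compounds shown here, methyl in place of hydrogen on an oxygen on an aromatic ring, which turns a hydroxy into a methoxy, gives a 4.0-fold higher number from compound 2 to compound 4 (0.60 log units; beyond the scatter), the first size reading for this position. The change leaves a measurable number, not a "not active" entry, so within this pair the free hydroxy at this oxygen is not required for a numeric read-out, although the hydroxy compound carries the lower number. Nothing at hand bears on why the number moves.

This single step sets no trend for the position. From the compounds shown here alone, whether a longer chain such as propyl on the same oxygen would extend the step or lose the number stays open, as does the effect of an amine in place of this hydroxy.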